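Diethylamino in place of amino: what to expect of compound 4

The source may report more compounds than this note shows. Statements on the series, on what has been measured and on what is new or still open speak of the compounds shown alone.

In an ADME assay on cells (Splenocyte, Mus musculus, strain BALB/c) for cytotoxicity, read by MTT assay, tested at 10 ug/mL (on this read-out higher numbers stand for a stronger effect at the one concentration tested and lower numbers for a weaker effect), compound 1 `CCCCCCCCCCCCCCC(N)CO` gives 20.2%, compound 2 `CCCCCCCCCCCCCCC(N)COCc1ccccc1` gives 12.2% and compound 3 `CCCCCCCCCCCCCCC(COCc1ccccc1)NCC` gives 11.9%. Compound 2 stands second highest of the three numbers, nearest to compound 3 and furthest from compound 1, both gaps within the scatter. Compound 4 `CCCCCCCCCCCCCCC(COCc1ccccc1)N(CC)CC` differs from compound 2 in one place: diethylamino in place of amino on a saturated chain carbon bound to two saturated chain carbons. The step bearing most directly on this is a number 0.3 percentage points lower from compound 2 to compound 3 (within the scatter), which also placed an ethyl on an amine nitrogen; the step of a number 8 percentage points lower from compound 1 to compound 2 (within the scatter) was likewise within the scatter. Going by the values given here, since no measured step moved the number beyond the scatter, compound 4 is expected to show no step beyond the scatter, the expected step being a number 0.2 percentage points lower from compound 2 to compound 4 (within the scatter). Compound 4 is therefore estimated at 12%, within 4% to 24%.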

Compound 4, a percentage reported as activity, at one concentration (the size of the read-out at that concentration, not a potency): 15.6%
Compound 4: the middle estimate sits 3.6 percentage points below what was measured; the range from low to high includes it.
By their numbers in this assay, from the lowest: compounds 3, 2, 4 and 1 (each within the scatter of the next).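

In this assay, diethylamino in place of amino on a saturated chain carbon bound to two saturated chain carbons gives a number 3.4 percentage points higher from compound 2 to compound 4 (within the scatter), and ethyl in place of hydrogen on an amine nitrogen gives a number 3.7 percentage points higher from compound 3 to compound 4 (within the scatter). The earlier compounds shown here showed this only for a single ethyl on this nitrogen; now two ethyl groups also leave the number within the scatter. No evidence at hand explains this tolerance.

The compounds shown leave open whether a butyl chain or an acetyl on this nitrogen would take the number beyond the scatter.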